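From Pentylamino to Piperidinyl on a Weak Binder

The source may hold more compounds than are shown below. What is called first, only, known or untested is meant among the compounds shown, and "the series" means these compounds.

The measured compounds are three. Compound 1 `CCCOc1ccc(C(=O)Nc2cnccn2)cc1` gives 22500 nM in an in vitro assay on HEK-tsA201 cells for antagonist activity at Neuronal acetylcholine receptor; alpha3/beta4 (Homo sapiens), read by fluorescence and calcium flux; a lower number here means a stronger inhibitor, a higher number a weaker inhibitor. Compound 2 `CCCOc1ccc(C(=O)Nc2cccc(CC)n2)cc1` gives 29200 nM in this assay. Compound 3 `CCCCCNc1cccc(NC(=O)c2ccc(OCCC)cc2)n1` gives only a limit in this assay, namely > 100000 nM.

Compound 3 therefore stands at the weak end of what is shown; no number is known for it, only that it falls beyond the limit of the measurement, as noted in the limit of > 100000 nM in this assay, at which 1 of the 3 values shown sits. Going by the values given here, the single measured step that touches this position is an at least 3.4-fold higher number from compound 2 to compound 3 (0.53 log units; beyond the scatter), a loss of at least modest size.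

Compound 4 `CCCOc1ccc(C(=O)Nc2cccc(N3CCCCC3)n2)cc1` has not yet been measured. It differs from compound 3 in one place: piperidin-1-yl in place of pentylamino on an aromatic carbon. The group that leaves and the group that enters are of the same size; the ring closes the chain and removes the hydrogen-bond donor. Among the compounds with values here, no measured step shows what a piperidin-1-yl does here, so the step of an at least 3.4-fold higher number from compound 2 to compound 3 (0.53 log units; beyond the scatter) is the only guide, and it points to this position tolerating substituents poorly.

Compound 4 is therefore expected to remain a weak inhibitor, with an at least 1.1-fold lower number from compound 3 to compound 4 (0.04 log units; that floor lies within the scatter) as the estimated step. The expected value for compound 4 in this assay is 90000 nM, within a range from 20000 nM to 300000 nM, with a fair chance that only a limit is reported again.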

Compound 4, half-maximal inhibitory concentration: > 100000 nM
Compound 4 was reported as a limit; the forecaster's own chance of this, stated with the estimate: 50%; at least 1.1-fold (0.04 log units) between middle value and limit.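

Closing the pentylamino chain into piperidin-1-yl, which also removes the hydrogen-bond donor, still gave no measurable number in this assay: compound 4, like compound 3, is reported only as a limit, so the step between them cannot be read. Measured against the ethyl group of compound 2, the ring shows the same kind of loss as the open chain, with an at least 3.4-fold higher number from compound 2 to compound 4 (0.53 log units; beyond the scatter), so at this position the loss does not require either the open chain or the hydrogen-bond donor of pentylamino. Both of these larger groups now leave the reading at the end of the measurable range: the limit of > 100000 nM in this assay, at which 2 of the 4 values shown sit.

How much weaker compound 3 and compound 4 really are stays unknown, and the compounds shown do not say whether the two groups differ from each other at all. As far as these compounds go, it also remains open where between ethyl and these larger groups the loss sets in, and whether a smaller amine such as dimethylamino, or a ring with a second hetero atom such as morpholin-4-yl, would hold the level of compound 2 at 29200 nM.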